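The source may report more compounds than this note shows. Statements on the series, on what has been measured and on what is new or still open speak of the compounds shown alone.

Compound 1 `CCCCOC(=O)[C@@]12C[C@@H]1[C@@H](n1cnc3c(NC)nc(C#Cc4ccc(Cl)s4)nc31)[C@H](O)[C@@H]2O`: 54%
Compound 2 `CNc1nc(C#Cc2ccc(Cl)s2)nc2c1ncn2[C@H]1[C@H](O)[C@H](O)[C@]2(C(=O)OCCC3CCCCC3)C[C@H]12`: 5%

In an assay on cells for displacement of a labelled ligand from adenosine receptor A3 (Mus musculus), read by scintillation counting and radioligand binding, with stated times of 10 min and 90 min, tested at 10 uM (a higher number here means more inhibition at the concentration tested (going by the name of the read-out), a lower number less inhibition), compound 1 gives 54%, the higher of the two numbers, while compound 2 gives 5%. For the measured compounds named here, the one measured step, a number 49 percentage points lower from compound 1 to compound 2 (beyond the scatter), is large and concerns the same ester chain. Compound 3 `CNc1nc(C#Cc2ccc(Cl)s2)nc2c1ncn2[C@H]1[C@H](O)[C@H](O)[C@]2(C(=O)OCc3ccccc3)C[C@H]12` differs from compound 1 by phenyl in place of propyl on a saturated chain carbon bound to an oxygen next to a carbonyl group. Since enlarging this chain in compound 2 cut the inhibition sharply, a drop is expected here as well, though the entering group is smaller than in compound 2. For compound 3 the expected value is 30% (range 5% to 60%). The expected step is a number 24 percentage points lower from compound 1 to compound 3 (beyond the scatter).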

Compound 3, a percentage reported as inhibition, at one concentration (the size of the read-out at that concentration, not a potency): 48%
Compound 3: the middle estimate sits 18 percentage points below what was measured, within the range that was stated.
By their numbers in this assay, from the lowest: compound 2; then compounds 3 and 1 (each within the scatter of the next).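

In this assay, benzyloxycarbonyl in place of butoxycarbonyl leaves the read-out within the scatter (a number 6 percentage points lower from compound 1 to compound 3 (within the scatter)), so this position accepts an aromatic ring on the chain. Phenyl in place of cyclohexylmethyl (a number 43 percentage points higher from compound 2 to compound 3 (beyond the scatter)) shows that the loss seen with compound 2 does not extend to every ring-bearing ester. No measurement given here accounts for these steps.

From the compounds shown here alone, how a phenethyl ester, a pyridylmethyl ester or a chlorobenzyl ester would read remains open. So does the effect of an amide in place of the ester.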